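Chloro in place of methoxy on compound 2

This account rests on a few compounds, and the source may have more. Where it says the series, first, only, none or still open, it means among the compounds named here.

Three analogues sharing one core differ only in what sits on a nitrogen of the aromatic ring, and those differences set the numbers in an in vitro assay on Ltk- cells for binding affinity to corticotropin-releasing factor receptor 1 (Homo sapiens); a lower number here means a stronger inhibitor, a higher number a weaker inhibitor. Compound 1 `CCCN(c1nc(-c2ccc(Cl)cc2OC)n(C)n1)C(C(C)C)C(C)C` gives 910 nM. Compound 3 `CCCCC(CC)N(CCC)c1nc(-c2ccc(Cl)cc2OC)n(C)n1` gives 46 nM. For compound 2 `CCCN(CCC)c1nc(-c2ccc(Cl)cc2OC)n(C)n1` this assay reports only a limit, > 10000 nM, so compound 2 stands at the limit of > 10000 nM in this assay, at which 1 of the 3 values shown sits, and its true number is not known. The measured steps all concern the group on the ring nitrogen: an at least 10-fold higher number from compound 1 to compound 2 (1.04 log units; beyond the scatter), a 20-fold lower number from compound 1 to compound 3 (1.30 log units; beyond the scatter) and an at least 210-fold lower number from compound 2 to compound 3 (2.33 log units; beyond the scatter). Compound 4 `CCCN(CCC)c1nc(-c2ccc(Cl)cc2Cl)n(C)n1` keeps the two propyl groups of compound 2 and differs elsewhere: chloro in place of methoxy on an aromatic carbon. Among the measured compounds shown here, none of the measured steps changes that position, so none bears on this step, and there is no ground to expect a step beyond the scatter in this assay. Because compound 2 stands at the limit of > 10000 nM in this assay, at which 1 of the 3 values shown sits, the result for compound 4 may again be a limit rather than a number. Compound 4 is therefore estimated at 15000 nM, between 4000 nM and 60000 nM, which means an expected step that the limit leaves unreadable from compound 2 to compound 4.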

Compound 4, inhibition constant: 3400 nM
Beside the measured number, compound 4's estimate is 4.4-fold (0.64 log units) above it; the measured number lies below the stated range.
By their numbers in this assay, from the lowest: compound 3; then compound 1; then compound 4. At a limit, above all of these: compound 2.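

With the two propyl groups held fixed, chloro in place of methoxy on an aromatic carbon ortho to a large group gives, in this assay, an at least 2.9-fold lower number from compound 2 to compound 4 (0.46 log units; beyond the scatter). Among the compounds shown here, the earlier steps all concerned the group on the ring nitrogen, so this is the only step that shows this aromatic carbon also bears on the number, and it does so beyond the scatter. The true size of the step remains unknown because compound 2 has only a limit and not a number: the limit of > 10000 nM in this assay, at which 1 of the 4 values shown sits.

For the compounds shown here, only this one pair carries the change, so it stays open whether the same exchange would shift the number with the 1-ethylpentyl group of compound 3 on the ring nitrogen. The compounds shown also leave open how a fluoro, methyl or hydroxy group would read on this aromatic carbon.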